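A few compounds are considered here, and "the series" means these few. Any claim that something is new, unique, unknown or untested is made for them only; others in the source may bear on it.

Measured compounds:
compound 1, `COc1cc(CNCc2ccncc2)ccc1OCc1cccc(F)c1`: 4800 nM
compound 2, `COc1cc(CNCc2cccs2)ccc1OCc1ccc(Cl)nc1`: 96000 nM

Both compounds were tested in a functional assay on HeLa cells (Homo sapiens) for inhibition, with a stated time of 72 h; on this read-out lower numbers stand for an effect already at smaller amounts and higher numbers for an effect only at larger amounts of compound. Of the two numbers, compound 1 stands lowest; the number for compound 2 lies well beyond the scatter above it. The two compounds differ in more than one place, so nothing more than what their values show can be drawn from that gap.

Compound 3, `COc1cc(CNCc2ccncc2)ccc1OCc1ccc(Cl)cc1Cl`, has not yet been measured. It differs from compound 1 in one place: 2,4-dichlorophenyl in place of 3-fluorophenyl on a saturated chain carbon bound to an oxygen on an aromatic ring. Among the compounds with values here, no measured pair isolates this change, so there is no step to lean on, and what follows rests on compound 1 alone, which gives 4800 nM in this assay. The expected step, a 1.6-fold lower number from compound 1 to compound 3 (0.20 log units; within the scatter), is modest, toward a somewhat lower number or none beyond the scatter. Compound 3 is therefore estimated at 3000 nM, with a range from 800 nM to 12000 nM, the width reflecting that the change itself has not been measured.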

Compound 3, half-maximal effective concentration: 3900 nM
Compound 3: the middle estimate sits 1.3-fold (0.11 log units) below what was measured; low and high end bracket the measured number.
By their numbers in this assay, from the lowest: compounds 3 and 1 (each within the scatter of the next); then compound 2.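

In this assay, putting 2,4-dichlorophenyl in place of 3-fluorophenyl on a saturated chain carbon bound to an oxygen on an aromatic ring gives a 1.2-fold lower number from compound 1 to compound 3 (0.09 log units; within the scatter), so this position accepts 2,4-dichlorobenzyl in place of 3-fluorobenzyl with no difference that can be told from the scatter. This single step holds both the loss of the fluorine and the arrival of the two chlorines, so it shows only the sum of the change and not the share of either. No measurement of any property of these groups accompanies the result, and nothing here tells what lies behind a step this small.

From the compounds shown here alone, whether this position would read the same with a group lacking the aromatic ring, such as cyclohexyl or a plain methyl, stays open, as does the effect of a carboxylic acid on the phenyl ring. Equally open, going by these compounds, is how an amide in place of the chain amine of the shared core would read with either of these benzyl groups kept.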